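Notes on replacing chloro with dimethylamino

The source may hold more compounds than are shown below. What is called first, only, known or untested is meant among the compounds shown, and "the series" means these compounds.

Measured so far in a functional assay on J774 cells (Mus musculus) for cytotoxicity, read by resazurin assay; a lower number here means a stronger inhibitor, a higher number a weaker inhibitor

compound 1 `OCCCCCC(O)c1ccc(-c2ccc(F)cc2)cc1` gives 18000 nM
compound 2 `Cc1ccc(-c2ccc(C(O)CCCCCO)cc2)cc1` gives 22000 nM
compound 3 `OCCCCCC(O)c1ccc(-c2ccc(Cl)cc2)cc1` gives 17000 nM

Compound 3 cannot be separated from the other two measured compounds. The numbers show a 1.1-fold lower number from compound 1 to compound 3 (0.02 log units; within the scatter) and a 1.3-fold lower number from compound 2 to compound 3 (0.11 log units; within the scatter) with both steps inside the scatter.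

The next compound is compound 4 `CN(C)c1ccc(-c2ccc(C(O)CCCCCO)cc2)cc1` which has dimethylamino in place of chloro on an aromatic carbon. The counted difference is dimethylamino in place of chloro on an aromatic carbon and the shared core is otherwise unchanged.

For the measured compounds named here, three measured steps bear on this change, since each swaps the group at this same place. Beside the two above stands a 1.2-fold higher number from compound 1 to compound 2 (0.09 log units; within the scatter) and so fluoro, methyl and chloro all read alike in this assay on these three compounds. None of these steps involves dimethylamino, and the data hold no measurement with this group. The flat result therefore supports only a cautious expectation, and a surprise remains possible.

Expected in this assay is a 1.1-fold higher number from compound 3 to compound 4 (0.02 log units; within the scatter) and thus no step beyond the scatter. For compound 4 the estimated value is 18000 nM with an expected range from 8000 nM to 38000 nM as the working figures.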

Compound 4, half-maximal inhibitory concentration: 28000 nM
Estimate against measurement, compound 4: 1.6-fold (0.19 log units) below; measured number inside the range.
By their numbers in this assay, from the lowest: compounds 3, 1, 2 and 4 (each within the scatter of the next).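

Replacing chloro with dimethylamino brings in 3 heavy atoms and 1 hydrogen-bond acceptor on an aromatic carbon para to a large group, yet this assay gives a 1.6-fold higher number from compound 3 to compound 4 (0.22 log units; within the scatter) as the step, so the flat reading at this place now extends beyond fluoro, methyl and chloro to a substituted amine. The two other steps agree, with a 1.3-fold higher number from compound 2 to compound 4 (0.10 log units; within the scatter) for the change from methyl and a 1.6-fold higher number from compound 1 to compound 4 (0.19 log units; within the scatter) for the change from fluoro, and all four compounds stay unseparated in this assay as a single group. Nothing at hand explains why the reading stays flat across these four groups.

Whether the same flat reading would hold at this place for a carboxylic acid, a primary amine or a morpholine ring stays open, since the four groups shown do not reach that far. All four compounds also share the same alcohol-bearing chain, so the compounds shown say nothing on how a shorter chain, a longer chain or an ether in its place would read.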